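The source may report more compounds than this note shows. Statements on the series, on what has been measured and on what is new or still open speak of the compounds shown alone.

Three compounds were measured in a functional assay on ACHN cells (Homo sapiens) for cytotoxicity, read by sulforhodamine B assay, with a stated time of 48 h, tested at 0.01 uM; on this read-out higher numbers stand for a weaker effect at the one concentration tested and lower numbers for a stronger effect:

compound 1 `COc1ccc(-c2cc(/C=C/C(=O)c3ccc(OC)c(OC)c3)[nH]n2)cc1` gives 100%
compound 2 `COc1cc(-c2cc(/C=C/C(=O)c3ccc(Cl)c(Cl)c3)[nH]n2)cc(OC)c1OC` gives 107%
compound 3 `COc1ccc(-c2cc(/C=C/C(=O)c3ccc(N)cc3)[nH]n2)cc1OC` gives 93%

Among these three numbers compound 2 stands highest. Compound 1 sits within the usual scatter of compound 2, so the two cannot be told apart on this read-out. Compound 3 sits beyond the scatter on the lower side, which on this read-out means a stronger effect than compound 2 at the one concentration tested.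

Compound 4 `COc1cc(-c2cc(/C=C/C(=O)c3ccc(F)c(F)c3)[nH]n2)cc(OC)c1OC` has not been measured in this assay. It differs from compound 2 in one place: 3,4-difluorophenyl in place of 3,4-dichlorophenyl on a carbonyl carbon. For the measured compounds named here, no pair of measured compounds differs in this way, so nothing measured tells how large such a step is. All three measured numbers lie close to the level of no effect, and the change keeps the same ring with two halogens in the same places. On that basis the step from compound 2 to compound 4 is expected to be small, estimated as a number 7 percentage points lower from compound 2 to compound 4 (within the scatter), not beyond the scatter in either direction. Compound 4 is therefore expected to give about 100% in this assay, with a range from 85% to 115%.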

Compound 4, a percentage reported as activity, at one concentration (the size of the read-out at that concentration, not a potency): 102%
Compound 4: middle estimate off by 2 percentage points, on the low side, within the range that was stated.
By their numbers in this assay, from the lowest: compounds 3, 1, 4 and 2 (each within the scatter of the next, the first and the last beyond it).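

In this assay, 3,4-difluorophenyl in place of 3,4-dichlorophenyl on the carbonyl carbon gives a number 5 percentage points lower from compound 2 to compound 4 (within the scatter). For the compounds shown here, this is the first direct measurement of a change at this place, and the two halogen pairs cannot be told apart on this read-out. No measurement shown bears on the reason for this result.

On these data alone, what remains open is whether a different kind of group on the carbonyl carbon, such as a pyridine ring or a 3,4-dimethylphenyl, would shift the number beyond the usual scatter. Also open, as far as these compounds go, is whether compound 2 and compound 4 would still read alike at a higher concentration, since a single low concentration close to the level of no effect says little about potency.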